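A few compounds are considered here, and "the series" means these few. Any claim that something is new, unique, unknown or untested is made for them only; others in the source may bear on it.

Measured so far in an assay on CHO-K1 cells for displacement of a labelled ligand from adenosine receptor A1 (Homo sapiens), read by scintillation counting, with a stated time of 60 min; a higher number here means a weaker inhibitor, a lower number a stronger inhibitor:
compound 1 `CSCC/C=N/Nc1nc(N)c2ncn([C@@H]3O[C@H](CO)[C@@H](O)[C@H]3O)c2n1`; compound 1 gives > 10000 nM, a limit of the assay.
compound 2 `Nc1nc(N/N=C/c2ccc(N3CCCC3)cc2)nc2c1ncn2[C@@H]1O[C@H](CO)[C@@H](O)[C@H]1O`; compound 2 gives 5.1 nM.
compound 3 `CCCOc1ccc(/C=N/Nc2nc(N)c3ncn([C@@H]4O[C@H](CO)[C@@H](O)[C@H]4O)c3n2)cc1`; compound 3 gives > 10000 nM, again a limit.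

Compound 3 therefore stands at the limit, as the limit of > 10000 nM in this assay, at which 2 of the 3 values shown sit, shows, and only compound 2 has a number. The move to compound 4 `CCCCc1nc(/C=N/Nc2nc(N)c3ncn([C@@H]4O[C@H](CO)[C@@H](O)[C@H]4O)c3n2)c(Cl)[nH]1` is 2-butyl-5-chloro-1H-imidazol-4-yl in place of 4-propoxyphenyl on a carbon with a double bond to nitrogen. Going by the values given here, the steps that bear on it are an at least 1900-fold higher number from compound 2 to compound 3 (3.29 log units; beyond the scatter) and an at least 1900-fold lower number from compound 1 to compound 2 (3.29 log units; beyond the scatter), both large, while a step that the two limits leave unreadable from compound 1 to compound 3. The 2-butyl-5-chloro-1H-imidazol-4-yl group has no measured neighbour. Compound 4 is expected to give 8000 nM, range 500 nM to 30000 nM. The expected step is an at least 1.2-fold lower number from compound 3 to compound 4 (0.09 log units; that floor lies within the scatter), which is read as no step beyond the scatter in this assay.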

Compound 4, inhibition constant: 12 nM
Estimate against measurement, compound 4: 670-fold (2.82 log units) above; measured number outside the range, below it.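

In this assay, a low number on the carbon with a double bond to nitrogen is no longer tied to 4-(pyrrolidin-1-yl)phenyl: 2-butyl-5-chloro-1H-imidazol-4-yl gives an at least 830-fold lower number from compound 3 to compound 4 (2.92 log units; beyond the scatter) and an at least 830-fold lower number from compound 1 to compound 4 (2.92 log units; beyond the scatter). The gap to the other compound with a number is small by comparison, with a 2.4-fold higher number from compound 2 to compound 4 (0.37 log units; beyond the scatter). The two large steps are floors, as each starts from a limit: the limit of > 10000 nM in this assay, at which 2 of the 4 values shown sit.

The compounds shown leave open which part of the 2-butyl-5-chloro-1H-imidazol-4-yl group carries the gain. On these data alone, how a pyridine ring or a carboxylic acid would read at this place also remains open.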